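A few compounds are considered here, and "the series" means these few. Any claim that something is new, unique, unknown or untested is made for them only; others in the source may bear on it.

Working notes on the series. In a functional assay on HepG2 cells (Homo sapiens) for antiproliferative activity, read by MTT assay, with a stated time of 48 h (on this read-out lower numbers stand for stronger inhibition and higher numbers for weaker inhibition), compound 1 (`CC(=O)N1N=C(c2ccc3ccccc3c2)OC1c1ccccc1`) gives 2.11 ug/mL and compound 2 (`CC(=O)N1N=C(c2ccc3ccccc3c2)OC1c1ccccc1F`) gives 3.36 ug/mL while compound 3 (`CC(=O)N1N=C(c2ccc3ccccc3c2)OC1c1cccc(F)c1`) gives 1.86 ug/mL and so stands within the scatter of both. Fluoro in place of hydrogen on an aromatic carbon gives a 1.6-fold higher number from compound 1 to compound 2 (0.20 log units; within the scatter) and also a 1.1-fold lower number from compound 1 to compound 3 (0.05 log units; within the scatter) while 3-fluorophenyl in place of 2-fluorophenyl gives a 1.8-fold lower number from compound 2 to compound 3 (0.26 log units; within the scatter) so all three measured changes on this aromatic group remain small. Compound 4 (`CC(=O)N1N=C(c2ccc3ccccc3c2)OC1c1cccnc1`) carries pyridin-3-yl in place of 3-fluorophenyl on a saturated ring carbon. Among the measured compounds shown here, no measured step brings a hetero atom into this aromatic ring, so these steps bear on the change only indirectly and the range is kept wide. The expected step is a 1.3-fold higher number from compound 3 to compound 4 (0.13 log units; within the scatter) and no shift beyond the scatter is anticipated. Compound 4 is estimated at 2.5 ug/mL with an expected range from 1 ug/mL to 6.5 ug/mL in this assay on present evidence.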

Compound 4, half-maximal inhibitory concentration: 2.86 ug/mL
The estimate for compound 4 lay 1.1-fold (0.06 log units) below the measured number; measured number inside the range.
By their numbers in this assay, from the lowest: compounds 3, 1, 4 and 2 (each within the scatter of the next).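

In this assay the series now holds a hetero atom in the aromatic ring on this saturated ring carbon, and pyridin-3-yl gives a 1.5-fold higher number from compound 3 to compound 4 (0.19 log units; within the scatter) against 3-fluorophenyl, a 1.2-fold lower number from compound 2 to compound 4 (0.07 log units; within the scatter) against 2-fluorophenyl and a 1.4-fold higher number from compound 1 to compound 4 (0.13 log units; within the scatter) against phenyl. The ring nitrogen and the hydrogen-bond acceptor counted with it therefore leave the number within the scatter of all three carbon-only rings, so this position has so far tolerated both fluoro and a ring nitrogen in this assay. No measurement on hand accounts for this result.

The compounds shown leave open whether an amine or a carboxylic acid on this aromatic ring, or a longer chain in its place, would move the number beyond the scatter. As far as these compounds go, whether replacing the acetyl group would do so also remains open.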